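Sulfonyl substituent series: aryl to benzyl(methyl)amino

This account rests on a few compounds, and the source may have more. Where it says the series, first, only, none or still open, it means among the compounds named here.

Three measured compounds share one core and differ only in the group on the sulfonyl sulfur. Compound 1 `COc1cccc(S(=O)(=O)c2ccccc2Cc2c3c(n(CC(=O)O)c2C)CCNC3=O)c1` gives 12 nM in a functional assay on CHO.K1 cells for antagonist activity at prostaglandin D2 receptor 2 (Homo sapiens), read by GTPgammaS binding, with a stated time of 1 h; on this read-out higher numbers stand for weaker inhibition and lower numbers for stronger inhibition. Compound 2 `Cc1c(Cc2ccccc2S(=O)(=O)c2ccc(Cl)cc2)c2c(n1CC(=O)O)CCNC2=O` gives 8.5 nM, and compound 3 `Cc1c(Cc2ccccc2S(=O)(=O)c2ccc(OC(F)(F)F)cc2)c2c(n1CC(=O)O)CCNC2=O` gives 6.6 nM. Compound 3 has the lowest number of the three, but the steps of a 1.8-fold lower number from compound 1 to compound 3 (0.26 log units; within the scatter) and a 1.3-fold lower number from compound 2 to compound 3 (0.11 log units; within the scatter) both stay within the scatter, as does a 1.4-fold lower number from compound 1 to compound 2 (0.15 log units; within the scatter); on the numbers shown the three compounds are not separated from one another.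

Compound 4 `Cc1c(Cc2ccccc2S(=O)(=O)N(C)Cc2ccccc2)c2c(n1CC(=O)O)CCNC2=O` carries the change (benzyl(methyl)amino in place of 4-(trifluoromethoxy)phenyl on a sulfonyl sulfur). The measured steps each exchange one substituent on a phenyl ring for another while the phenyl itself stays on the sulfonyl sulfur; none of them removes that phenyl, so they bear on the new compound only by showing that three variations of the sulfonyl substituent have produced no step beyond the scatter. Whether a benzyl(methyl)amino group on the sulfonyl sulfur behaves like a substituted phenyl is not known from these data. The expectation is a step of a 3.8-fold higher number from compound 3 to compound 4 (0.58 log units; beyond the scatter) toward a higher number, held with a wide range. Compound 4 is estimated at 25 nM, between 5 nM and 150 nM.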

Compound 4, half-maximal inhibitory concentration: 26 nM
Estimate against measurement, compound 4: 1.0-fold (0.02 log units) below; measured number inside the range.
By their numbers in this assay, from the lowest: compounds 3, 2 and 1 (each within the scatter of the next); then compound 4.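

Benzyl(methyl)amino on the sulfonyl sulfur gives the first steps beyond the scatter at this position in this assay, with a 3.9-fold higher number from compound 3 to compound 4 (0.60 log units; beyond the scatter) and a 3.1-fold higher number from compound 2 to compound 4 (0.49 log units; beyond the scatter) and also a 2.2-fold higher number from compound 1 to compound 4 (0.34 log units; beyond the scatter) as modest moves toward weaker inhibition. The three phenyl groups had not been separated from one another, so this position is now shown to respond to the group on sulfur, though only modestly, as compound 4 at 26 nM still keeps inhibition in this assay with a nitrogen rather than an aromatic carbon attached to the sulfonyl sulfur and one six-membered aromatic ring of carbon still present in the entering group. No measured evidence accounts for these steps.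

Compound 4 changes several features together, so the compounds shown do not separate the contribution of the nitrogen on sulfur, its methyl and the benzyl group. A benzylamino group with the nitrogen hydrogen retained, a dimethylamino group or a piperidine on the sulfonyl sulfur would show which of these features goes with the higher number.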